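The compounds below may be only part of what the source reports. "The series", "measured", "known", "first", "only" and "open" are said of these compounds alone.

In an ADME assay on microsomes from liver (Homo sapiens) for metabolic stability (on this read-out higher numbers stand for fast clearance and lower numbers for slow clearance), compound 1 `CCCC(Oc1ccc(-n2cc3ccccc3n2)cc1)c1ccc(C(=O)NCCC(=O)O)cc1`, which carries a 2H-indazol-2-yl group, gives 44 mL/min/kg. Compound 2 `CCCC(Oc1ccc(-n2cc(C(F)(F)F)c(C)n2)cc1)c1ccc(C(=O)NCCC(=O)O)cc1` gives < 10 mL/min/kg, which is a limit and not a number. Compound 3 `CCCC(Oc1ccc(-n2cc(C#N)cn2)cc1)c1ccc(C(=O)NCCC(=O)O)cc1` gives < 8 mL/min/kg, which is also a limit and not a number. Between these two limits there is a step that the two limits leave unreadable from compound 2 to compound 3. Compound 3 therefore stands at the low end of the numbers shown, alongside compound 2. Both replacements of the 2H-indazol-2-yl group lowered the read-out, with an at least 4.4-fold lower number from compound 1 to compound 2 (0.64 log units; beyond the scatter) and an at least 5.5-fold lower number from compound 1 to compound 3 (0.74 log units; beyond the scatter).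

Compound 4 `CCCC(Oc1ccc(-n2cc3c(n2)CCCC3)cc1)c1ccc(C(=O)NCCC(=O)O)cc1` departs from compound 3 through (a group of 9 heavy atoms (7 carbon, 2 nitrogen; one five-membered aromatic ring with 2 hetero atoms, one six-membered non-aromatic ring of carbon only) in place of a group of 7 heavy atoms (4 carbon, 3 nitrogen; one five-membered aromatic ring with 2 hetero atoms), on an aromatic carbon). Like the 2H-indazol-2-yl group of compound 1, the entering group has a six-membered ring as well as its five-membered aromatic ring, although here that ring is non-aromatic. The steps from compound 1 therefore bear on this change when read in reverse. A rise beyond the scatter is expected, going part of the way back towards compound 1 at 44 mL/min/kg. The estimate amounts to an at least 2.5-fold higher number from compound 3 to compound 4 (0.39 log units; beyond the scatter). For compound 4 the expected value is 20 mL/min/kg, with an estimated range of 8 mL/min/kg to 45 mL/min/kg.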

Compound 4, clearance: 48 mL/min/kg
For compound 4 the middle estimate is 2.4-fold (0.38 log units) below the measured one; measured number outside the range, above it.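

In this assay the new pair shows a 1.1-fold higher number from compound 1 to compound 4 (0.04 log units; within the scatter), so an aromatic and a non-aromatic six-membered ring in this group cannot be told apart on this read-out. Against the groups that have only the five-membered aromatic ring, the read-out shows an at least 6.0-fold higher number from compound 3 to compound 4 (0.77 log units; beyond the scatter) and an at least 4.8-fold higher number from compound 2 to compound 4 (0.68 log units; beyond the scatter), and among these four compounds the two groups with a six-membered ring sit high and the two without one sit low. Compound 2 and compound 3 each stand at a limit and not a number, so these two steps give only a lower bound.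

No measurement shown gives a cause for this gap. Going by these compounds, whether the second ring or the nitrile and trifluoromethyl groups set it remains open, and a plain 1H-pyrazol-1-yl group or a six-membered ring carrying an amine would bear on that.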